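Swapping the aryl group on a sulfonamide nitrogen

This account rests on a few compounds, and the source may have more. Where it says the series, first, only, none or still open, it means among the compounds named here.

Measured compounds:
- compound 1, `O=C1NCCN1c1ccc(S(=O)(=O)Nc2ccc3[nH]ccc3c2)cc1`, 87 nM
- compound 2, `Cc1ccc(NS(=O)(=O)c2ccc(N3CCNC3=O)cc2)cc1C`, 94 nM

Both compounds were tested in a functional assay on M21 cells (Homo sapiens) for antiproliferative activity, read by sulforhodamine B assay, with a stated time of 48 h; on this read-out lower numbers stand for stronger inhibition and higher numbers for weaker inhibition. Compound 1 gives 87 nM and compound 2 gives 94 nM. These two numbers lie within the usual scatter of one another, so compound 2 stands level with compound 1 and neither can be called the stronger.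

Compound 3, `O=C1NCCN1c1ccc(S(=O)(=O)Nc2cccc(Cl)c2)cc1`, has not yet been measured. It differs from compound 2 in one place: 3-chlorophenyl in place of 3,4-dimethylphenyl on a sulfonamide nitrogen. Among the measured compounds shown here, no measured pair shows what such a change does here, so the expected step in this assay can rest only on the two values in hand, which agree with each other across two rather different aryl groups. A small shift toward a weaker value, at most a modest one, is expected for the step of a 1.6-fold higher number from compound 2 to compound 3 (0.20 log units; within the scatter). Compound 3 is therefore estimated at 150 nM, within a range from 50 nM to 500 nM.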

Compound 3, half-maximal inhibitory concentration: 25 nM
For compound 3 the middle estimate is 6.0-fold (0.78 log units) above the measured one, outside the stated range (below it).
By their numbers in this assay, from the lowest: compound 3; then compounds 1 and 2 (each within the scatter of the next).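

In this assay the aryl group on the sulfonamide nitrogen clearly matters: 3-chlorophenyl in place of 3,4-dimethylphenyl gives a 3.8-fold lower number from compound 2 to compound 3 (0.58 log units; beyond the scatter) for this single change. The two earlier compounds gave matching values despite their rather different aryl groups, which could have suggested that swapping the group here does little; compound 3 shows that the number can move with the group at this position. No evidence is at hand to explain why this swap lowers the number.

The swap adds a chlorine and also removes the methyl groups, so the compounds shown leave open which of these changes drives the step. Also open, as far as these compounds go, is how this position would respond to other groups, such as 4-chlorophenyl or a phenyl ring carrying an amine.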